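The source may hold more compounds than are shown below. What is called first, only, known or untested is meant among the compounds shown, and "the series" means these compounds.

The series shares one core, carried by compound 3 `Cc1nc(S(C)(=O)=O)ccc1Oc1ncnc(OC2CCN(C(=O)C3CCCC3)CC2)c1F`, which has a cyclopentyl on the carbonyl carbon. In a functional assay on isolated protein for inhibition of Glucose-dependent insulinotropic receptor (Rattus norvegicus), read by HTRF and cAMP accumulation (a higher number here means that more compound is needed for the effect, a lower number that less compound is needed), compound 3 gives 407 nM, the second highest of the three numbers recorded. Compound 1 `Cc1nc(S(C)(=O)=O)ccc1Oc1ncnc(OC2CCN(C(=O)OC(C)(C)CF)CC2)c1F` gives 138 nM, and compound 2 `Cc1nc(S(C)(=O)=O)ccc1Oc1ncnc(OC2CCN(C(=O)OC3COC3)CC2)c1F` gives 2500 nM. The steps among these three all turn on the carbonyl group: an 18-fold higher number from compound 1 to compound 2 (1.26 log units; beyond the scatter); a 2.9-fold higher number from compound 1 to compound 3 (0.47 log units; beyond the scatter); a 6.1-fold lower number from compound 2 to compound 3 (0.79 log units; beyond the scatter). Every one of them lies beyond the scatter, so this position is plainly sensitive.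

Compound 4 `Cc1nc(S(C)(=O)=O)ccc1Oc1ncnc(OC2CCN(C(=O)c3noc(C(C)(C)F)n3)CC2)c1F` differs from compound 3 by a single change: a group of 9 heavy atoms (5 carbon, 2 nitrogen, 1 oxygen, 1 fluorine; one five-membered aromatic ring with 3 hetero atoms) in place of a group of 5 heavy atoms (5 carbon; one five-membered non-aromatic ring of carbon only), on a carbonyl carbon. Among the compounds with values here, no measured step places an aromatic ring on this carbonyl carbon, so the three recorded steps bear on the question only in showing how wide the spread at this position can be. The incoming group carries a fluorine, as does the group of compound 1, which gave the lowest number seen, while compound 2, with its oxetan-3-yl, gave the highest. On balance a step of a 1.6-fold lower number from compound 3 to compound 4 (0.21 log units; within the scatter) is expected, modest and within the spread already seen. Compound 4 is therefore estimated at 250 nM in this assay, with a range from 60 nM to 1000 nM.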

Compound 4, half-maximal effective concentration: 103 nM
Compound 4: the middle estimate sits 2.4-fold (0.39 log units) above what was measured, within the range that was stated.
By their numbers in this assay, from the lowest: compounds 4 and 1 (each within the scatter of the next); then compound 3; then compound 2.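

Placing a group with a five-membered aromatic ring on this carbonyl carbon gives, for the first time, a direct reading of such a ring in this assay, and the step is a 4.0-fold lower number from compound 3 to compound 4 (0.60 log units; beyond the scatter) when it replaces cyclopentyl. Set against the (oxetan-3-yl)oxy group, the same ring gives a 24-fold lower number from compound 2 to compound 4 (1.39 log units; beyond the scatter) and so widens the spread seen at this position, while a 1.3-fold lower number from compound 1 to compound 4 (0.13 log units; within the scatter) shows that it cannot be told apart from the open-chain group of compound 1. Among these four compounds the two groups carrying fluorine hold the two lowest numbers and no compound goes against this, although fluorine never changes alone here, so the pattern rests on groups that also differ in other ways.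

Nothing available accounts for these differences. Whether the step comes from the aromatic ring itself or from the fluorine it carries stays open, as does how a plain phenyl or a tert-butyl on the carbonyl carbon would compare with the groups shown, and a matching aromatic ring without fluorine would be needed to separate the two.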